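Notes on a pyridin-4-yl step in the series

This account rests on a few compounds, and the source may have more. Where it says the series, first, only, none or still open, it means among the compounds named here.

In a functional assay on KG-1 cells (Homo sapiens) for cytotoxicity, read by luminescence and CellTiter-Glo, with a stated time of 3 days (a higher number here means a weaker inhibitor, a lower number a stronger inhibitor), compound 3 `N#Cc1ccc(NC(=O)c2ccccc2O)cc1` gives 5370 nM and stands within the scatter of compound 2 `N#Cc1ccc(NC(=O)c2ccc(-c3cccnc3)cc2O)cc1` at 7940 nM while compound 1 `N#Cc1ccc(NC(=O)c2ccc(Cl)cc2O)cc1` gives a lower 1920 nM on the same scale. Compound 4 `N#Cc1ccc(NC(=O)c2ccc(-c3ccncc3)cc2O)cc1` differs from compound 3 by pyridin-4-yl in place of hydrogen on an aromatic carbon with pyridin-4-yl in place of hydrogen on an aromatic carbon, meta to a hydroxy group. The nearest measured step is a 1.5-fold lower number from compound 2 to compound 3 (0.17 log units; within the scatter) with hydrogen in place of pyridin-3-yl, and it lies within the scatter. The steps of a 4.1-fold higher number from compound 1 to compound 2 (0.62 log units; beyond the scatter) and a 2.8-fold higher number from compound 1 to compound 3 (0.45 log units; beyond the scatter) are modest but both start from chloro, which compound 4 lacks. Pyridin-4-yl itself has no measured precedent. No step beyond the scatter is therefore expected in this assay and the estimated change is a 1.2-fold higher number from compound 3 to compound 4 (0.07 log units; within the scatter) for this pair. Compound 4 is estimated at 6300 nM with an expected range from 2500 nM to 16000 nM in this series.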

Compound 4, half-maximal inhibitory concentration: 8840 nM
The estimate for compound 4 lay 1.4-fold (0.15 log units) below the measured number; low and high end bracket the measured number.
By their numbers in this assay, from the lowest: compound 1; then compounds 3, 2 and 4 (each within the scatter of the next).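

In this assay the place of the ring nitrogen does not separate the two pyridinyl compounds at this position, with a 1.1-fold higher number from compound 2 to compound 4 (0.05 log units; within the scatter) for pyridin-4-yl in place of pyridin-3-yl. Pyridin-4-yl in place of hydrogen likewise stays within the scatter, giving a 1.6-fold higher number from compound 3 to compound 4 (0.22 log units; within the scatter) and leaving chloro as the only substituent shown that stands apart, through a 4.6-fold higher number from compound 1 to compound 4 (0.66 log units; beyond the scatter) for pyridin-4-yl in place of chloro. No available measurement accounts for these numbers.

From the compounds shown here alone, whether bromo or fluoro would match chloro here remains open. So does the effect of an amine or a carboxylic acid at this position.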